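Difluorophenyl ether analogue in the gastric cell assay

This account rests on a few compounds, and the source may have more. Where it says the series, first, only, none or still open, it means among the compounds named here.

Measured compounds:
Compound 1 `Cc1nnsc1CO/N=C/c1c(C)nn(C)c1Oc1ccc(F)cc1` gives > 50000 nM in a functional assay on SGC-7901 cells (Homo sapiens) for inhibition, read by MTT assay, with a stated time of 48 h (a higher number here means a weaker inhibitor, a lower number a stronger inhibitor), which is a limit of the assay.
Compound 2 `Cc1nnsc1CO/N=C/c1c(C)nn(C)c1Oc1ccccc1OC(F)(F)F` gives > 50000 nM in this assay, again a limit.
Compound 3 `Cc1nnsc1CO/N=C/c1c(C)nn(C)c1Oc1ccc(C(C)(C)C)cc1` gives > 50000 nM in this assay, also a limit.

Compound 1 therefore stands only at a limit in this assay, and the other two measured compounds stand at the same limit, as the limit of > 50000 nM in this assay, at which 3 of the 3 values shown sit, records. Among the measured compounds shown here, the one single-point step among them, a step that the two limits leave unreadable from compound 1 to compound 3, cannot be read, since both ends are limits.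

Compound 4 `Cc1nnsc1CO/N=C/c1c(C)nn(C)c1Oc1cccc(F)c1F` differs from compound 1 in one place: 2,3-difluorophenyl in place of 4-fluorophenyl on an oxygen on an aromatic ring. For the measured compounds named here, no measured step bears on this change in a readable way, and the only comparison available, a step that the two limits leave unreadable from compound 1 to compound 3, shows that altering the same aryl ring left compound 3 at the limit. Compound 4 is therefore expected to remain near the limit, and its estimate is 70000 nM, within 25000 nM to 200000 nM. The step that this estimate implies, a step that the limit leaves unreadable from compound 1 to compound 4, is expected to be none beyond the scatter.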

Compound 4, half-maximal inhibitory concentration: 25700 nM
Beside the measured number, compound 4's estimate is 2.7-fold (0.44 log units) above it; low and high end bracket the measured number.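

In this assay compound 4 alone among those shown gives a number rather than a limit, so a change in the aryl group on this oxygen can bring the shared core into the readable range: the limit of > 50000 nM in this assay, at which 3 of the 4 values shown sit.

Placing 2,3-difluorophenyl in place of 4-fluorophenyl gives an at least 1.9-fold lower number from compound 1 to compound 4 (0.28 log units; that floor lies within the scatter), and only this floor is known, since compound 1 stands at a limit. The other step, with limits at both ends, still cannot be read.

The compounds shown leave open whether the added fluorine or the changed fluorine positions account for the number of compound 4. They also leave open how far this position tolerates quite different groups on the aryl ring, such as an amine or a carboxylic acid.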